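The compounds below may be only part of what the source reports. "The series", "measured", "known", "first", "only" and "open" are said of these compounds alone.

Measured compounds:

- Compound 1, `N#Cc1c(F)c(Cl)c2nc(N)nc(N)c2c1F`: 30.8 ug/mL
- Compound 2, `N#Cc1c(F)c(F)c2nc(N)nc(N)c2c1F`: > 1000 ug/mL
- Compound 3, `CCN(CC)c1c(C#N)c(F)c2c(N)nc(N)nc2c1Cl`: 7.1 ug/mL

All three were tested in a functional assay on A549 cells (Homo sapiens) for cytotoxicity, read by MTT assay; a lower number here means a stronger inhibitor, a higher number a weaker inhibitor. Compound 1 gives 30.8 ug/mL. Compound 2 gives > 1000 ug/mL, which is a limit of the assay rather than a number, the limit described as the limit of > 1000 ug/mL in this assay, at which 1 of the 3 values shown sits. Compound 3 gives 7.1 ug/mL, the lowest number among the measured compounds.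

Two single changes connect these compounds. From compound 1 to compound 2 the change is fluoro in place of chloro on an aromatic carbon, and the step is an at least 32-fold higher number from compound 1 to compound 2 (1.51 log units; beyond the scatter). From compound 1 to compound 3 the change is diethylamino in place of fluoro on an aromatic carbon, and the step is a 4.3-fold lower number from compound 1 to compound 3 (0.64 log units; beyond the scatter).

Compound 4, `CCN(CC)c1c(C#N)c(F)c2c(N)nc(N)nc2c1F`, has not been measured. It differs from compound 3 by fluoro in place of chloro on an aromatic carbon. This is the same kind of change as from compound 1 to compound 2, though the surroundings are not identical: in compound 1 the changed carbon is ortho to a fluoro group, whereas in compound 3 it is ortho to a diethylamino group. Going by the values given here, since the one measured example of this change, an at least 32-fold higher number from compound 1 to compound 2 (1.51 log units; beyond the scatter), was large, the step from compound 3 to compound 4 is expected to be a 35-fold higher number from compound 3 to compound 4 (1.55 log units; beyond the scatter), although a single precedent with different surroundings is thin support. Compound 4 is therefore estimated at 250 ug/mL, within a range from 30 ug/mL to 1000 ug/mL, and a limit rather than a number would not be surprising.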

Compound 4, half-maximal inhibitory concentration: 26.5 ug/mL
Beside the measured number, compound 4's estimate is 9.4-fold (0.97 log units) above it; measured number outside the range, below it.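

Fluoro in place of chloro gives a 3.7-fold higher number from compound 3 to compound 4 (0.57 log units; beyond the scatter) in this assay, so the direction seen on the core of compound 1 carries over to the core bearing diethylamino, but the size of the step does not: the same change on two cores in this assay, an at least 32-fold higher number (1.51 log units; beyond the scatter) from compound 1 to compound 2 and a 3.7-fold higher number (0.57 log units; beyond the scatter) from compound 3 to compound 4, at least 8.6-fold (0.93 log units) apart, beyond the scatter of two such steps

Diethylamino in place of fluoro gives an at least 37-fold lower number from compound 2 to compound 4 (1.57 log units; beyond the scatter), so this change also keeps its direction on the second core while differing in size: the same change on two cores in this assay, a 4.3-fold lower number (0.64 log units; beyond the scatter) from compound 1 to compound 3 and an at least 37-fold lower number (1.57 log units; beyond the scatter) from compound 2 to compound 4, at least 8.6-fold (0.93 log units) apart, beyond the scatter of two such steps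

Together these two pairs show that the size of each change depends on what else the molecule carries, but they do not show why, and the value of compound 2 is a limit and not a number, so the full gap between the steps remains unknown: the limit of > 1000 ug/mL in this assay, at which 1 of the 4 values shown sits.

The compounds shown leave open what a bromo or a methyl group would give in place of the chloro, and whether a smaller dimethylamino group or a ring amine such as morpholine would act as diethylamino does. They also leave open whether the same two changes would keep their direction if the cyano group were replaced by a carboxylic acid.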